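Swapping an Ether for a Thioether on the Benzyl Arm

The compounds below may be only part of what the source reports. "The series", "measured", "known", "first", "only" and "open" are said of these compounds alone.

Compound 3 `Cc1ccc2[nH]c(=O)c(CN(Cc3ccc(OC(C)C)cc3)Cc3ccc(C(C)(C)C)cc3)cc2c1` was tested in a toxicity assay on MDCK cells (Canis lupus familiaris) for cytotoxicity, read by crystal violet staining, with a stated time of 48 h (on this read-out lower numbers stand for higher toxicity in this test and higher numbers for lower toxicity in this test), and compound 3 gives > 5000 nM, which is a limit of the assay and not a number. Compound 1 `Cc1ccc2cc(CN(Cc3ccc(C(C)C)cc3)Cc3cccc(F)c3)c(=O)[nH]c2c1` gives > 33000 nM in this assay, again only a limit. Compound 2 `Cc1cccc2cc(CN(Cc3ccc(F)cc3)Cc3ccc(C(C)(C)C)cc3)c(=O)[nH]c12` has no result in this assay, its entry reading "not determined" (no result reported). Compound 3 therefore stands among readings of which none is a single number: its own is a limit, one further reading is a limit, and one entry carries no number at all. The two limits are the limit of > 33000 nM in this assay, at which 1 of the 3 values shown sits, and (the limit of > 5000 nM in this assay, at which 1 of the 3 values shown sits).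

Compound 4 `Cc1ccc2[nH]c(=O)c(CN(Cc3ccc(SC(F)F)cc3)Cc3ccc(C(C)(C)C)cc3)cc2c1` differs from compound 3 in one place: (difluoromethyl)sulfanyl in place of isopropoxy on an aromatic carbon. Within the data shown here, no step between two measured compounds is available here to set a scale for this change. The step that the limit leaves unreadable from compound 3 to compound 4 is expected to be no change beyond the scatter, since the only reference is a limit. Compound 4 is accordingly expected to give 20000 nM in this assay, with a range of 5000 nM to 100000 nM, most likely again reported only as a limit.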

Compound 4, half-maximal cytotoxic concentration: > 5000 nM
Compound 4: no number, only a limit; the forecaster's own chance of this, stated with the estimate: 70%; the middle value is on the limit's open side.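

Among these compounds, compound 3 and compound 4 are both reported in this assay only as limits of the assay, and no step between them can be read. The compounds shown leave open whether (difluoromethyl)sulfanyl in place of isopropoxy changes the cytotoxic concentration at all, and at what concentration either compound becomes toxic.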